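Dithiocarbamate amine variation on the chromone core

A few compounds are considered here, and "the series" means these few. Any claim that something is new, unique, unknown or untested is made for them only; others in the source may bear on it.

Measured so far in a functional assay on HeLa cells (Homo sapiens) for antiproliferative activity, read by MTT assay, with a stated time of 72 h; on this read-out lower numbers stand for stronger inhibition and higher numbers for weaker inhibition:
compound 1, `Cc1ccc2c(=O)c(CSC(=S)N3CCCC3)coc2c1`, 4400 nM
compound 2, `Cc1ccc2c(=O)c(CSC(=S)N(C(C)C)C(C)C)coc2c1`, 1400 nM

Both compounds share the same core and differ only in the amine on the thiocarbonyl carbon. Within the data shown here, the one measured step, a 3.1-fold lower number from compound 1 to compound 2 (0.50 log units; beyond the scatter), is beyond the scatter and marks the open-chain diisopropylamino group as the one that gave the lower number. Compound 2 therefore stands lowest of the two numbers, with compound 1 the nearest and higher.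

Compound 3, `Cc1ccc2c(=O)c(CSC(=S)N3CCOCC3)coc2c1`, has not been measured. It differs from compound 2 as follows: morpholin-4-yl in place of diisopropylamino on a thiocarbonyl carbon. The change goes back to a ring on the nitrogen, which is the direction the step from compound 1 to compound 2 ran against; that step is the only one bearing on it. A return to a ring is therefore expected to move the number up in this assay, by about the size of the measured step, and compound 3 is expected to show a 3.6-fold higher number from compound 2 to compound 3 (0.55 log units; beyond the scatter). The estimate for compound 3 is 5000 nM, within a range of 1500 nM to 16000 nM.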

Compound 3, half-maximal inhibitory concentration: 6100 nM
For compound 3 the middle estimate is 1.2-fold (0.09 log units) below the measured one; measured number inside the range.
By their numbers in this assay, from the lowest: compound 2; then compounds 1 and 3 (each within the scatter of the next).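

In this assay, the change to morpholin-4-yl on the thiocarbonyl carbon gives a 4.4-fold higher number from compound 2 to compound 3 (0.64 log units; beyond the scatter) and so sets diisopropylamino apart from a second ring, not only from pyrrolidin-1-yl. The comparison of the two rings, a 1.4-fold higher number from compound 1 to compound 3 (0.14 log units; within the scatter) within this series, shows no difference beyond the scatter, so the ring oxygen of morpholin-4-yl leaves no readable mark on the number, and across these three compounds the split runs between the open-chain group and the rings, with none going against it. Nothing available explains why the open-chain group and the two rings separate in this way.

As far as these compounds go, a single open-chain group carries this split, so it remains open whether the lower number belongs to open-chain amines in general or to diisopropylamino alone, a question that diethylamino or dimethylamino on the thiocarbonyl carbon would address. Also open, from the compounds shown here alone, is whether other rings would group with these two, as piperidin-1-yl or 4-methylpiperazin-1-yl would show.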